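The compounds below may be only part of what the source reports. "The series", "measured", "known", "first", "only" and "open" are said of these compounds alone.

Three thiazolidine-type compounds have been tested in an ADME assay on TERT-RPE1 cells (Homo sapiens) for cytotoxicity, read by MTT assay, with a stated time of 72 h; on this read-out lower numbers stand for stronger inhibition and higher numbers for weaker inhibition. Compound 1 `C=C1CN/C(=N/c2ccccc2)S1` gives only a limit of the assay, > 100000 nM, and not a number. Compound 2 `COc1ccc(/C=C2\S/C(=N\c3ccccc3)N(C)C2=O)cc1` likewise reaches only a limit in this assay, > 100000 nM, so no number stands for it. Going by the values given here, compound 3 `COc1ccc(/C=C2/CN(C)/C(=N/c3ccc(C(C)(C)C)cc3)S2)cc1` is the one member of the set with a measured number, giving 23500 nM in this assay. Compound 2 therefore stands at the edge of what this assay can report, sharing that position with compound 1 at the limit of > 100000 nM in this assay, at which 2 of the 3 values shown sit.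

Compound 4 `COc1ccc(/C=C2\S/C(=N\c3ccc(OC)cc3)N(C)C2=O)cc1` has not yet been measured in this assay. It differs from compound 2 by methoxy in place of hydrogen on an aromatic carbon. Among the compounds with values here, no pair of measured compounds differing in a single place is available, so the size of the step cannot be read from a comparable case. The expectation is that the step of a number no higher from compound 2 to compound 4 (the limit leaves the size open) brings no change beyond the usual scatter, leaving compound 4 in the same weakly cytotoxic region. Compound 4 is accordingly estimated at 100000 nM, with a range from 30000 nM to 300000 nM, and the result may well again be reported only as a limit.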

Compound 4, half-maximal inhibitory concentration: > 100000 nM
Compound 4 was reported as a limit (the forecaster's own chance of this, stated with the estimate: 70%); the middle value lies on the limit itself.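

In this assay compound 4 is reported only as a limit, as compound 2 is, so no step can be read between compound 2 and compound 4: the limit of > 100000 nM in this assay, at which 3 of the 4 values shown sit. The compounds shown leave open whether methoxy in place of hydrogen on an aromatic carbon changes this read-out at all.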